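Naphthol series: benzyloxy in place of methyl on the pendant ring

A few compounds are considered here, and "the series" means these few. Any claim that something is new, unique, unknown or untested is made for them only; others in the source may bear on it.

Measured so far:
compound 1 `Cc1ccc(Cc2ccc3ccccc3c2O)cc1` 24 nM
compound 2 `Oc1c(Cc2cccnc2)ccc2ccccc12` 230 nM

In an assay on RBL-1 cells with Polyunsaturated fatty acid 5-lipoxygenase (Rattus norvegicus) as the target (a higher number here means a weaker inhibitor, a lower number a stronger inhibitor), compound 1 gives 24 nM, the lowest of the two numbers at hand. For the measured compounds named here, compound 2 gives 230 nM in this assay, a higher number that lies beyond the scatter; no single-point step between these two is worked out, so only the two values themselves are noted.

Compound 3 `Oc1c(Cc2ccc(OCc3ccccc3)cc2)ccc2ccccc12` is unmeasured. It differs from compound 1 by benzyloxy in place of methyl on an aromatic carbon, para to a large group on the pendant ring of the shared core. Going by the values given here, no measured pair shows this kind of change, so there is no step to lean on. The expectation is a step of no more than modest size from compound 1 to compound 3, a 1.0-fold higher number from compound 1 to compound 3 (0.02 log units; within the scatter), and none clearly beyond the scatter in either direction. Compound 3 is therefore estimated at 25 nM in this assay, with a range from 6 nM to 100 nM.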

Compound 3, half-maximal inhibitory concentration: 72 nM
The estimate for compound 3 lay 2.9-fold (0.46 log units) below the measured number; the range from low to high includes it.
By their numbers in this assay, from the lowest: compound 1; then compound 3; then compound 2.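

In this assay, the aromatic carbon para to a large group accepts far more than methyl: benzyloxy brings 8 heavy atoms and one six-membered aromatic ring in place of 1 heavy atom, and the change gives a 3.0-fold higher number from compound 1 to compound 3 (0.48 log units; beyond the scatter). The step is modest in size, so this enlargement costs some inhibition without abolishing it, and compound 3 still reads 72 nM. No measurement at hand accounts for the size of this step.

From the compounds shown here alone, it remains open whether the step follows from the ether oxygen, the added ring or the overall length of the group, a question that methoxy or phenyl at the same carbon would help to separate. Going by these compounds, how an amine or a carboxylic acid would fare at this carbon also remains open.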